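A few compounds are considered here, and "the series" means these few. Any claim that something is new, unique, unknown or untested is made for them only; others in the source may bear on it.

Compound 1, `C[C@H](NC(=O)CN(c1nc(Cl)nc2[nH]cnc12)C1CC1)C(=O)O`, gives 28.4% in a functional assay on the whole organism (Tail, strain ICR) with Mus musculus as the target, in the tail flick test, with a stated time of 120 min, at a dose of 25 umol/kg by the oral route; a higher number here means a stronger effect of the compound at the dose given, a lower number a weaker effect.
Compound 2, `O=C(O)C[C@H](NC(=O)CN(c1nc(Cl)nc2[nH]cnc12)C1CC1)C(=O)O`, gives 22%.
Compound 3, `N=C(N)NCCC[C@H](NC(=O)CN(c1nc(Cl)nc2[nH]cnc12)C1CC1)C(=O)O`, gives 17%.

Of these three numbers, compound 3 stands lowest: compound 2 lies nearest, within the scatter, while compound 1 lies furthest, beyond it (a number 11.4 percentage points lower from compound 1 to compound 3 (beyond the scatter)). Compound 4, `NC(=O)C[C@H](NC(=O)CN(c1nc(Cl)nc2[nH]cnc12)C1CC1)C(=O)O`, has not yet been measured. It differs from compound 3 in one place: a group of 3 heavy atoms (1 carbon, 1 nitrogen, 1 oxygen; no ring) in place of a group of 6 heavy atoms (3 carbon, 3 nitrogen; no ring), on a saturated chain carbon, two bonds along the chain from an amide-type nitrogen and a carbonyl carbon. The step bearing most on this change is the one in the opposite direction, a number 5 percentage points lower from compound 2 to compound 3 (within the scatter), which stayed within the scatter; the larger step of a number 11.4 percentage points lower from compound 1 to compound 3 (beyond the scatter) replaced a hydrogen rather than a comparable group. A small rise, or none beyond the scatter, is therefore expected, a number 5 percentage points higher from compound 3 to compound 4 (within the scatter). For compound 4 the estimate is 22%, ranging from 13% to 31%.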

Compound 4, a percentage reported as activity, at one dose (the size of the read-out at that dose, not a potency): 17%
Beside the measured number, compound 4's estimate is 5 percentage points above it; low and high end bracket the measured number.
By their numbers in this assay, from the lowest: compounds 3, 4, 2 and 1 (each within the scatter of the next, the first and the last beyond it).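

In this assay, the carbamoyl group on the saturated chain carbon cannot be told apart from the larger group of compound 3 (no change at the digits printed from compound 3 to compound 4 (within the scatter)), and amino in place of hydroxy on the carbonyl carbon also stays within the scatter (a number 5 percentage points lower from compound 2 to compound 4 (within the scatter)). Carbamoyl in place of hydrogen, however, gives a step beyond the scatter (a number 11.4 percentage points lower from compound 1 to compound 4 (beyond the scatter)), so compound 4 joins compound 3 in lying clearly apart from compound 1, while compound 2 does not. Nothing measured here explains these numbers. The compounds shown leave open whether a simple amine, or a longer chain ending in carbamoyl, at this place would read like compound 1 or like compound 4.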